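Swapping the Amide Aryl Group on a Bis-Indole Core

A few compounds are considered here, and "the series" means these few. Any claim that something is new, unique, unknown or untested is made for them only; others in the source may bear on it.

Measured compounds in a functional assay on BGC-823 cells (Homo sapiens) for cytotoxicity, read by MTT assay, with a stated time of 72 h; on this read-out lower numbers stand for stronger inhibition and higher numbers for weaker inhibition:
compound 1 `COc1ccc(C(=O)NC[C@H]2c3[nH]c4ccccc4c3C[C@H]3[C@H]4c5[nH]c6ccccc6c5C[C@@H]([C@H](C#N)N23)N4C)cc1`: 320 nM
compound 2 `CN1[C@@H]2c3[nH]c4ccccc4c3C[C@H]1[C@H](C#N)N1[C@@H](CNC(=O)c3ccc4ccccc4n3)c3[nH]c4ccccc4c3C[C@@H]21`: 80 nM

Going by the values given here, compound 2 holds the lower of the two numbers so far, and its nearest neighbour is compound 1, the pair being separated by a 4.0-fold lower number from compound 1 to compound 2 (0.60 log units; beyond the scatter). Compound 3 `CN1[C@@H]2c3[nH]c4ccccc4c3C[C@H]1[C@H](C#N)N1[C@@H](CNC(=O)c3cc4ccccc4[nH]3)c3[nH]c4ccccc4c3C[C@@H]21` differs from compound 2 by 1H-indol-2-yl in place of quinolin-2-yl on a carbonyl carbon. Among the compounds with values here, the only step that bears on this change is the earlier swap of the aryl group on the same carbonyl carbon, a 4.0-fold lower number from compound 1 to compound 2 (0.60 log units; beyond the scatter), which shows that this position responds to the aryl group at a modest scale. Both groups in the present change are bicyclic, so the expected step in this assay is smaller and has no settled direction, a 1.3-fold higher number from compound 2 to compound 3 (0.10 log units; within the scatter). Compound 3 is therefore estimated at 100 nM, with a range from 30 nM to 320 nM.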

Compound 3, half-maximal inhibitory concentration: 1690 nM
Compound 3: the middle estimate sits 17-fold (1.23 log units) below what was measured, outside the stated range (above it).
By their numbers in this assay, from the lowest: compound 2; then compound 1; then compound 3.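

In this assay, the change on this carbonyl carbon gives a 21-fold higher number from compound 2 to compound 3 (1.32 log units; beyond the scatter), so two bicyclic aryl groups are far from interchangeable here, and this step is larger than the earlier swap of aryl groups at the same place. The further step, a 5.3-fold higher number from compound 1 to compound 3 (0.72 log units; beyond the scatter), shows that ring count does not set the order among these amides: quinolin-2-yl gives the lowest number of the three, 1H-indol-2-yl gives the highest, and 4-methoxyphenyl, with its single ring, falls in the middle. Nothing available explains the gap between quinolin-2-yl and 1H-indol-2-yl.

The compounds shown leave open whether the higher number goes with the five-membered ring or with the hydrogen-bond donor that enters with 1H-indol-2-yl. From the compounds shown here alone, a 1-methyl-1H-indol-2-yl group would help separate the two, and whether the order holds in other cell lines also remains open.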